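Swapping Fluoro for Chloro on a Weak Antagonist

A few compounds are considered here, and "the series" means these few. Any claim that something is new, unique, unknown or untested is made for them only; others in the source may bear on it.

Measured so far:
Compound 1, `CCC(CC)n1c(-c2ccc(OCc3c(-c4c(Cl)cccc4Cl)noc3C(C)C)cc2F)nc2ccc(C(=O)O)cc21`: > 10000 nM
Compound 2, `CC(C)c1onc(-c2c(Cl)cccc2Cl)c1COc1ccc(-c2nc3ccc(C(=O)O)cc3n2CC2CCCCC2)c(F)c1`: 840 nM

In an assay on HEK-293T cells for antagonist activity at vitamin D3 receptor (Homo sapiens), read by a luciferase reporter, with a stated time of 24 h (on this read-out higher numbers stand for weaker inhibition and lower numbers for stronger inhibition), compound 1 gives > 10000 nM, which is a limit of the assay rather than a number. Compound 2 gives 840 nM. For the measured compounds named here, the one measured step, an at least 11-fold lower number from compound 1 to compound 2 (1.07 log units; beyond the scatter), arises from putting cyclohexylmethyl in place of pentan-3-yl on an aromatic nitrogen, so it tells how the group on that nitrogen matters, and nothing more.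

Compound 3, `CCC(CC)n1c(-c2ccc(OCc3c(-c4c(Cl)cccc4Cl)noc3C(C)C)cc2Cl)nc2ccc(C(=O)O)cc21`, keeps the pentan-3-yl of compound 1 and differs from it only by chloro in place of fluoro on an aromatic carbon. No measured step touches a halogen on that carbon ring, so there is no shown evidence of how this swap moves the number. The plain expectation is therefore a step of no size beyond the scatter, with compound 3 remaining close to compound 1, which itself sits at the limit (the limit of > 10000 nM in this assay, at which 1 of the 2 values shown sits). Compound 3 is thus estimated at 15000 nM, in the range 3000 nM to 60000 nM. The step this estimate implies, a step that the limit leaves unreadable from compound 1 to compound 3, is expected to stay within the scatter.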

Compound 3, half-maximal inhibitory concentration: 1010 nM
Compound 3: middle estimate off by 15-fold (1.17 log units), on the high side; the measured number lies below the stated range.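

In this assay the swap of chloro in place of fluoro on an aromatic carbon gives an at least 9.9-fold lower number from compound 1 to compound 3 (0.99 log units; beyond the scatter) and so shows that this halogen position matters. Until now, only the group on the aromatic nitrogen had been seen to move the number. From the compounds shown here alone, compound 1 gives > 10000 nM and that is a limit, not a number, so the true size of the step stays unknown because of it: the limit of > 10000 nM in this assay, at which 1 of the 3 values shown sits.

The compounds shown leave open whether the gain is specific to chloro or would also appear with another group on the same carbon, such as bromo, methyl or a nitrile. They also leave open whether chloro on that carbon and cyclohexylmethyl on the aromatic nitrogen, each of which gives a lower number than compound 1 when placed on it alone, would add together in a single compound or would instead give no more than either change does by itself.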